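The source may report more compounds than this note shows. Statements on the series, on what has been measured and on what is new or still open speak of the compounds shown alone.

Working notes on the series, read in an ADME assay on microsomes from liver (Mus musculus) for metabolic stability, read by LC-MS, using NADPH, with a stated time of 10 min, tested at 10 uM; on this read-out higher numbers stand for a longer-lived compound and lower numbers for a shorter-lived compound. Compound 1 `Nc1ncnc2c1c(Oc1cc(O)ccn1)nn2C1CCC(F)(F)CC1` gives 1.13 h as its half-life. Compound 2 `N#Cc1ccnc(Oc2nn([C@H]3C[C@H](O)C3)c3ncnc(N)c23)c1` gives > 2.41 h as its entry, and this is a limit of the assay, not a number. From the compounds shown here alone, compound 2 therefore sits on the limit and its true half-life is unknown. The record so far is short, with the limit of > 2.41 h in this assay, at which 1 of the 2 values shown sits, as its main feature.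

Compound 3 `CC(C)(C)n1nc(Oc2cc(C#N)ccn2)c2c(N)ncnc21` has tert-butyl in place of 3-hydroxycyclobutyl on an aromatic nitrogen. Going by the values given here, no pair of measured compounds differs in one place, so no measured step guides this change. The expectation rests on two readings alone. Compound 1, without the 3-hydroxycyclobutyl group, reads 1.13 h as a true number, so a number rather than a limit is a reasonable expectation for compound 3. The expected change is an at least 1.2-fold lower number from compound 2 to compound 3 (0.10 log units; that floor lies within the scatter) in this assay, a modest downward step that may not clear the usual scatter. For compound 3 the estimate is 1.9 h, with 0.9 h to 3.6 h as the expected range for the half-life.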

Compound 3, half-life: 0.767 h
Compound 3: middle estimate off by 2.5-fold (0.39 log units), on the high side; the whole stated range lies above it.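

In this assay, going by these compounds alone, tert-butyl in place of 3-hydroxycyclobutyl on the aromatic nitrogen gives an at least 3.1-fold lower number from compound 2 to compound 3 (0.49 log units; beyond the scatter), the only measured step at this position so far. With this change, compound 3 gives a true number of 0.767 h, and the swap of this one group is enough to move the read-out by more than the usual scatter. The step gives only a lower bound on the size of the change, because the entry for compound 2 is a limit of the assay and not a number: the limit of > 2.41 h in this assay, at which 1 of the 3 values shown sits.

The step does not separate the loss of the hydroxy group from the loss of the four-membered ring, and a plain cyclobutyl or a 3-aminocyclobutyl group on the same nitrogen would tell these two apart. From the compounds shown here alone, compound 1 differs from compound 2 and from compound 3 in more than one place, so its steps to them cannot be read, and how far the pyridine-side group counts on its own stays open.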